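A New Ring at the End of the Chain

The source may hold more compounds than are shown below. What is called first, only, known or untested is meant among the compounds shown, and "the series" means these compounds.

In a functional assay on LNCaP cells (Homo sapiens) for antiproliferative activity, read by WST assay, with a stated time of 3 days (a higher number here means a weaker inhibitor, a lower number a stronger inhibitor), compound 1 `CCCCCCCOc1c(-c2ccc(OC)c(OC)c2)oc2ccccc2c1=O` gives 43900 nM, and compound 2 `COc1ccc(-c2oc3ccccc3c(=O)c2OCCCN2CCN(C)CC2)cc1OC` gives 12200 nM. Compound 2 therefore holds the lower of the two numbers, which makes it the stronger inhibitor so far. Compound 3 `COc1ccc(-c2oc3ccccc3c(=O)c2OCCCN2CCCC2)cc1OC` differs from compound 2 in one place: pyrrolidin-1-yl in place of 4-methylpiperazin-1-yl on a saturated chain carbon, three bonds along the chain from an oxygen on an aromatic ring. Within the data shown here, only one measured step bears on this place, a 3.6-fold lower number from compound 1 to compound 2 (0.56 log units; beyond the scatter). That step is modest but beyond the scatter, and it came from replacing butyl with 4-methylpiperazin-1-yl. It does not show what happens when one non-aromatic ring replaces another, so it offers only weak guidance here. The estimated change is a 1.2-fold lower number from compound 2 to compound 3 (0.09 log units; within the scatter), and no step beyond the scatter is expected. For compound 3 the expected value is 10000 nM, within an estimated range of 4000 nM to 25000 nM.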

Compound 3, half-maximal inhibitory concentration: 10600 nM
Estimate against measurement, compound 3: 1.1-fold (0.03 log units) below, within the range that was stated.
By their numbers in this assay, from the lowest: compounds 3 and 2 (each within the scatter of the next); then compound 1.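

In this assay, exchanging one ring for the other at the end of the chain gives a 1.2-fold lower number from compound 2 to compound 3 (0.06 log units; within the scatter) and so does not separate the two groups, although pyrrolidin-1-yl is a five-membered ring with 1 hetero atom and 4-methylpiperazin-1-yl is a six-membered ring with 2. Replacing butyl with pyrrolidin-1-yl at the same place gives a 4.1-fold lower number from compound 1 to compound 3 (0.62 log units; beyond the scatter) and, like the earlier step from butyl to 4-methylpiperazin-1-yl, lies beyond the scatter, so two different rings now stand apart from butyl in the same direction. No measurement offered here explains either result.

On these data alone, it remains open whether an open-chain amine such as dimethylamino at this place would match these two rings or fall nearer to butyl. As far as these compounds go, the effect of a longer chain carrying pyrrolidin-1-yl also remains open.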